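The source may report more compounds than this note shows. Statements on the series, on what has been measured and on what is new or still open speak of the compounds shown alone.

Measured in a functional assay on T47D cells (Homo sapiens) for antiproliferative activity, read by MTT assay, with a stated time of 48 h; a lower number here means a stronger inhibitor, a higher number a weaker inhibitor:
compound 1, `Cc1ccc(NC(=O)Nc2nnc(Sc3ncnc4scc(-c5ccncc5)c34)s2)cc1Cl`; compound 1 gives 34800 nM
compound 2, `Cc1ccc(NC(=O)Nc2nnc(Sc3ncnc4scc(-c5ccncc5)c34)s2)cc1`; compound 2 gives 17800 nM
compound 3, `O=C(Nc1ccc(F)cc1)Nc1nnc(Sc2ncnc3scc(-c4ccncc4)c23)s1`; compound 3 gives 18900 nM

Compound 3 stands second highest of the three numbers. Its nearest neighbour is compound 2, and the step of a 1.1-fold higher number from compound 2 to compound 3 (0.03 log units; within the scatter) lies within the scatter, as does a 1.8-fold lower number from compound 1 to compound 3 (0.27 log units; within the scatter). Compound 4 is `O=C(Nc1ccc(Cl)cc1)Nc1nnc(Sc2ncnc3scc(-c4ccncc4)c23)s1`. The change from compound 3 is chloro in place of fluoro on an aromatic carbon, the chloro entering on an aromatic carbon of a six-membered aromatic ring of carbon only, para to a large group. Among the compounds with values here, two measured steps touch the same ring: a 2.0-fold lower number from compound 1 to compound 2 (0.29 log units; within the scatter), hydrogen in place of chloro, and a 1.1-fold higher number from compound 2 to compound 3 (0.03 log units; within the scatter), fluoro in place of methyl. Both lie within the scatter, and so does a 1.8-fold lower number from compound 1 to compound 3 (0.27 log units; within the scatter), which changes the whole aryl group at once. Halogen substitution on this ring has so far left the numbers in this assay unmoved beyond the scatter, so no step beyond the scatter is expected in either direction. Compound 4 is expected to show the step of a 1.1-fold higher number from compound 3 to compound 4 (0.02 log units; within the scatter). The estimate for compound 4 is 20000 nM, with a range from 8000 nM to 50000 nM.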

Compound 4, half-maximal inhibitory concentration: 23300 nM
Compound 4: middle estimate off by 1.2-fold (0.07 log units), on the low side, within the range that was stated.
By their numbers in this assay, from the lowest: compounds 2, 3, 4 and 1 (each within the scatter of the next).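

In this assay, within the data shown here, the first exchange of one halogen for another at this position, a 1.2-fold higher number from compound 3 to compound 4 (0.09 log units; within the scatter), lies within the scatter. Chloro in place of methyl, a 1.3-fold higher number from compound 2 to compound 4 (0.12 log units; within the scatter), and 4-chlorophenyl in place of 3-chloro-4-methylphenyl, a 1.5-fold lower number from compound 1 to compound 4 (0.17 log units; within the scatter), also lie within the scatter, so these numbers do not separate fluoro, chloro and methyl at this position. Nothing available bears on why the values stay so close.

From the compounds shown here alone, whether an amine or a carboxylic acid at this position would give a step beyond the scatter stays open. Going by these compounds, all four compounds share the same core, so the effect of a change there also stays open.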